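The source may hold more compounds than are shown below. What is called first, only, known or untested is meant among the compounds shown, and "the series" means these compounds.

In a functional assay on M21 cells (Homo sapiens) for antiproliferative activity, read by sulforhodamine B assay, with a stated time of 48 h (a higher number here means a weaker inhibitor, a lower number a stronger inhibitor), compound 3 `O=C1NCCN1c1ccc(S(=O)(=O)Nc2ccccc2)cc1` gives 200 nM. Compound 1 `Cc1ccc(NS(=O)(=O)c2ccc(N3CCNC3=O)cc2)cc1`, which carries methyl in place of that hydrogen, gives 260 nM, and compound 2 `CCc1ccc(NS(=O)(=O)c2ccc(N3CCNC3=O)cc2)cc1`, which carries ethyl there, gives 480 nM. Compound 3 thus cannot be told apart from compound 1, and it stands modestly clear of compound 2.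

Compound 4 `CC(C)(C)c1ccc(NS(=O)(=O)c2ccc(N3CCNC3=O)cc2)cc1` is compound 3 with tert-butyl in place of hydrogen on an aromatic carbon, para to a large group: tert-butyl in place of hydrogen on an aromatic carbon.

The closest guides are the two measured steps that remove a group from this same place: a 1.3-fold lower number from compound 1 to compound 3 (0.11 log units; within the scatter), and a 2.4-fold lower number from compound 2 to compound 3 (0.38 log units; beyond the scatter). Read in reverse, only the ethyl step shows that adding a group here can raise the number, and the methyl step shows nothing beyond the scatter. Among the compounds with values here, no measured compound carries tert-butyl, so the size of the step remains uncertain. A rise somewhat larger than the ethyl step seems likely, and the expected step is a 3.8-fold higher number from compound 3 to compound 4 (0.57 log units; beyond the scatter). For compound 4 the estimated value is 750 nM, with an expected range of 300 nM to 2000 nM.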

Compound 4, half-maximal inhibitory concentration: > 1000 nM
Compound 4 ended at the assay's limit; the forecaster's own chance of this, stated with the estimate: 3%; at least 1.3-fold (0.12 log units) between middle value and limit.
By their numbers in this assay, from the lowest: compounds 3, 1 and 2 (each within the scatter of the next, the first and the last beyond it). At a limit, above all of these: compound 4.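

In this assay compound 4 reads > 1000 nM, which is a limit and not a number: the limit of > 1000 nM in this assay, at which 1 of the 4 values shown sits. Even so, the steps can be read as minimum sizes, giving an at least 5.0-fold higher number from compound 3 to compound 4 (0.69 log units; beyond the scatter), an at least 3.8-fold higher number from compound 1 to compound 4 (0.58 log units; beyond the scatter) and an at least 2.0-fold higher number from compound 2 to compound 4 (0.31 log units; beyond the scatter). Before this result, only ethyl stood clear of hydrogen at this place, whereas tert-butyl stands clear of hydrogen, methyl and ethyl alike, so a carbon group here can cost more activity than ethyl did, by an amount that remains unknown.

These four compounds cannot separate the number of carbons from branching, and a straight propyl or butyl chain would be needed to do so. They also say nothing about non-carbon groups here, such as an amine, a methoxy group or a carboxylic acid.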